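This account rests on a few compounds, and the source may have more. Where it says the series, first, only, none or still open, it means among the compounds named here.

Compound 1 `Fc1ccc(C2CC(c3ccc(Cl)s3)=NN2c2nc(-c3ccc(Cl)cc3)cs2)cc1` stands at a limit of the assay rather than at a number: in an ADME assay on NIH3T3 cells (Mus musculus) for cytotoxicity, read by XTT assay, with a stated time of 24 h (on this read-out higher numbers stand for weaker inhibition and lower numbers for stronger inhibition), compound 1 gives > 500 ug/mL. Compound 2 `Cc1ccc(-c2csc(N3N=C(c4ccc(C)s4)CC3c3ccc(F)cc3)n2)cc1` likewise sits at a limit, giving > 500 ug/mL in this assay. Compound 3 `Cc1ccc(C2=NN(c3nc(-c4ccc([N+](=O)[O-])cc4)cs3)C(c3ccc(F)cc3)C2)s1` gives a number in this assay, 15.6 ug/mL. Within the data shown here, the one measured step here is an at least 32-fold lower number from compound 2 to compound 3 (1.50 log units; beyond the scatter), and it starts from the limit of > 500 ug/mL in this assay, at which 2 of the 3 values shown sit, so its true size is bounded only from below. Compound 4 `CS(=O)(=O)c1ccc(-c2csc(N3N=C(c4ccc(Cl)s4)CC3c3ccc(F)cc3)n2)cc1` differs from compound 1 by methylsulfonyl in place of chloro on an aromatic carbon. Among the measured compounds shown here, no measured step exchanges chloro for methylsulfonyl; the step from compound 2 to compound 3 concerns nitro on the same ring and so bears on compound 4 only loosely. Taking that step as the sole guide, a drop of some size from compound 1 seems possible, yet compound 1 starting at a limit leaves the step of an at least 3.3-fold lower number from compound 1 to compound 4 (0.52 log units; beyond the scatter) as an expectation with wide bounds. Compound 4 is therefore expected to give 150 ug/mL in this assay, between 25 ug/mL and 500 ug/mL.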

Compound 4, half-maximal inhibitory concentration: > 500 ug/mL
Compound 4 ended at the assay's limit; the forecaster's own chance of this, stated with the estimate: 45%; middle value at least 3.3-fold (0.52 log units) from the limit.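

Among these compounds, compound 1 and compound 4 both sit at a limit of this assay, so no step between them can be read: the limit of > 500 ug/mL in this assay, at which 3 of the 4 values shown sit. The compounds shown leave open whether methylsulfonyl in place of chloro shifts the read-out in this assay at all, and where the true value of either compound lies.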